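The source may report more compounds than this note shows. Statements on the series, on what has been measured and on what is new or still open speak of the compounds shown alone.

Measured in a functional assay on A549 cells (Homo sapiens) for cytotoxicity, read by MTT assay, with a stated time of 72 h; on this read-out lower numbers stand for stronger inhibition and higher numbers for weaker inhibition:
- compound 1 `CN1CCN(CCCCCCn2c3c(c4ccccc42)C(=O)c2c[n+]([O-])c4ccccc4c2C3=O)CC1`, 330 nM
- compound 2 `O=C1c2c[n+]([O-])c3ccccc3c2C(=O)c2[nH]c3ccccc3c21`, 320 nM
- compound 3 `O=C1c2c[n+]([O-])c3ccccc3c2C(=O)c2c1c1ccccc1n2CCCCN1CCNCC1`, 540 nM

On these three numbers compound 1 stands second highest in this assay, with compound 2 nearest and compound 3 furthest; every gap between the three lies within the scatter, so no order among them can be read.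

Compound 4 `O=C1c2c[n+]([O-])c3ccccc3c2C(=O)c2c1c1ccccc1n2CCN1CCCC1` is not yet measured. It differs from compound 1 by pyrrolidin-1-yl in place of 4-(4-methylpiperazin-1-yl)butyl on a saturated chain carbon, two bonds along the chain from an aromatic nitrogen.

Going by the values given here, two measured steps bear on this change. Varying the group at the end of the chain gave a 1.6-fold higher number from compound 1 to compound 3 (0.21 log units; within the scatter). Adding the whole chain to the shared core gave a 1.7-fold higher number from compound 2 to compound 3 (0.23 log units; within the scatter). Neither step reaches beyond the scatter, so the substituent on the aromatic nitrogen has so far not moved the read-out in this assay in any resolvable way. For compound 4 the expectation is therefore a step of a 1.2-fold higher number from compound 1 to compound 4 (0.08 log units; within the scatter), not beyond the scatter. Compound 4 is estimated at 400 nM, with a range of 180 nM to 900 nM.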

Compound 4, half-maximal inhibitory concentration: 410 nM
The estimate for compound 4 lay 1.0-fold (0.01 log units) below the measured number, within the range that was stated.
By their numbers in this assay, from the lowest: compounds 2, 1, 4 and 3 (each within the scatter of the next).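

In this assay, the shorter side chain with a five-membered ring can now be set against both longer piperazine chains: pyrrolidin-1-yl in place of 4-(4-methylpiperazin-1-yl)butyl gives a 1.2-fold higher number from compound 1 to compound 4 (0.09 log units; within the scatter), and pyrrolidin-1-yl in place of 2-(piperazin-1-yl)ethyl gives a 1.3-fold lower number from compound 3 to compound 4 (0.12 log units; within the scatter). Adding 2-(pyrrolidin-1-yl)ethyl in place of hydrogen on the aromatic nitrogen gives a 1.3-fold higher number from compound 2 to compound 4 (0.11 log units; within the scatter), so across these four compounds neither the ring at the chain end nor the chain length has moved the read-out beyond the scatter. No measurement in hand accounts for this flat response.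

Chain and ring change together in compound 4, so a 2-(4-methylpiperazin-1-yl)ethyl group would be needed to separate them. As far as these compounds go, whether any group here can resolve a difference remains open, for instance a chain ending in a carboxylic acid rather than an amine.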